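The compounds below may be only part of what the source reports. "The series", "measured", "known", "first", "only" and "open" are said of these compounds alone.

In a functional assay on MCF7 cells (Homo sapiens) for antiproliferative activity, read by MTT assay, with a stated time of 48 h (on this read-out lower numbers stand for stronger inhibition and higher numbers for weaker inhibition), compound 1 `COc1ccccc1-n1nncc1CN1C(=O)C2(C(C#N)=C(N)Oc3c2c2nc4ccccc4nc2c2ccccc32)c2ccccc21` gives only a limit, > 50000 nM. Compound 2 `Cc1ccc(-n2nncc2CN2C(=O)C3(C(C#N)=C(N)Oc4c3c3nc5ccccc5nc3c3ccccc43)c3ccccc32)c(C)c1` likewise returns a limit in this assay, > 50000 nM. The step that the two limits leave unreadable from compound 1 to compound 2 is 2,4-dimethylphenyl in place of 2-methoxyphenyl on an aromatic nitrogen. Compound 3 `CC(=O)Nc1ccc(-n2nncc2CN2C(=O)C3(C(C#N)=C(N)Oc4c(N)cc5nc6ccccc6nc5c43)c3ccccc32)cc1` also stands at a limit in this assay, > 50000 nM. All three therefore share (the limit of > 50000 nM in this assay, at which 3 of the 3 values shown sit), and none of the three values is a number that can be compared.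

Compound 4 `N#CC1=C(N)Oc2c(N)cc3nc4ccccc4nc3c2C12C(=O)N(Cc1cnnn1-c1c(F)cccc1F)c1ccccc12` has not yet been measured. It differs from compound 3 by 2,6-difluorophenyl in place of 4-acetamidophenyl on an aromatic nitrogen. Within the data shown here, no measured step touches this group, and the single measured step cannot be sized, so nothing in hand points either way. The three values shown give no sign of activity within the measurable range. Compound 4 is therefore expected to give about 60000 nM in this assay, between 20000 nM and 200000 nM, most probably reported again as a limit. The expected step is a step that the limit leaves unreadable from compound 3 to compound 4, that is, no readable change.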

Compound 4, half-maximal inhibitory concentration: > 50000 nM
Compound 4 gave a limit, no number; the forecaster's own chance of this, stated with the estimate: 80%; the middle value lies beyond the limit too.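

Among these compounds, compound 3 and compound 4 both stand at a limit, so the step between them cannot be read and no new step emerges: the limit of > 50000 nM in this assay, at which 4 of the 4 values shown sit. The compounds shown leave open whether any structure in this series would give a measurable value in this assay.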